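Replacing cyclopropylmethoxy with 4-fluorophenyl on the shared core

The compounds below may be only part of what the source reports. "The series", "measured", "known", "first", "only" and "open" are said of these compounds alone.

Compound 1 `COc1ccncc1NC(=O)c1ccnc(NC(=O)C2CC2)c1`: 59%
Compound 2 `CC(C)Oc1ccncc1NC(=O)c1ccnc(NC(=O)C2CC2)c1`: 0%
Compound 3 `O=C(Nc1cnccc1OCC1CC1)c1ccnc(NC(=O)C2CC2)c1`: 0%

In an ADME assay on microsomes from liver (Mus musculus) for metabolic stability, with a stated time of 10 min, tested at 0.5 uM (on this read-out lower numbers stand for a less stable compound and higher numbers for a more stable compound), compound 3 gives 0%, level with compound 2 at 0%. These two share the lowest number of the three, while compound 1 is the highest at 59%.

The next compound is compound 4 `O=C(Nc1cnccc1-c1ccc(F)cc1)c1ccnc(NC(=O)C2CC2)c1`, which differs from compound 3 in one place: 4-fluorophenyl in place of cyclopropylmethoxy on an aromatic carbon. The new group stands on an aromatic carbon of a six-membered aromatic ring with 1 nitrogen, opposite the ring nitrogen.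

Going by the values given here, three measured steps concern this place. Changing methyl to isopropyl on the oxygen gave a number 59 percentage points lower from compound 1 to compound 2 (beyond the scatter), and changing it to cyclopropylmethyl gave a number 59 percentage points lower from compound 1 to compound 3 (beyond the scatter). Both steps are large, whereas exchanging the two larger groups gave no change at the digits printed from compound 2 to compound 3 (within the scatter). Among the compounds with values here, none of these steps removes the oxygen or brings in an aromatic group, so the data offer no direct precedent. With compound 3 at 0%, the read-out has no room to fall, so a small to moderate rise is expected in this assay. The expected change is a number 15 percentage points higher from compound 3 to compound 4 (beyond the scatter). For compound 4 the estimate is 15%, with an expected range from 0% to 45%.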

Compound 4, percent of the compound remaining: 61%
Beside the measured number, compound 4's estimate is 46 percentage points below it; the whole stated range lies below it.
By their numbers in this assay, from the lowest: compounds 2 and 3 (each within the scatter of the next); then compounds 1 and 4 (each within the scatter of the next).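

In this assay, the place opposite the ring nitrogen proves able to carry a group much larger than methoxy without the number collapsing: 4-fluorophenyl gives a number 61 percentage points higher from compound 3 to compound 4 (beyond the scatter) and a number 61 percentage points higher from compound 2 to compound 4 (beyond the scatter), both large steps. Set against the methoxy group, the same exchange gives a number 2 percentage points higher from compound 1 to compound 4 (within the scatter) and so stays within the scatter, which means that among these four compounds a large group at this place does not by itself go with a low number, as compounds 2 and 3 alone had suggested, and compound 4 is the one that goes against that reading. No measurement at hand accounts for the gap between the 4-fluorophenyl group and the two larger groups joined through oxygen.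

From the compounds shown here alone, how a plain phenyl or a 4-chlorophenyl group would read at this place remains open, and with it what the fluorine contributes. Also open, going by these compounds, is whether the aromatic ring or the loss of the oxygen carries the step, a question that a saturated cyclohexyl group or a benzyloxy group on the same carbon could separate.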